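The source may report more compounds than this note shows. Statements on the series, on what has been measured and on what is new or still open speak of the compounds shown alone.

Working notes: in a toxicity assay on MT4 cells (Homo sapiens) for cytotoxicity, read by MTT assay, with a stated time of 5 days (on this read-out lower numbers stand for higher toxicity in this test and higher numbers for lower toxicity in this test), compound 1 `Cc1cnc(Nc2ccc(C#N)cc2)nc1Nc1c(F)cc(-c2cccnc2)cc1F` gives 1100 nM and compound 2 `Cc1cnc(Nc2ccc(C#N)cc2)nc1Nc1c(F)cc(-c2cncnc2)cc1F` gives 900 nM, so compound 2 stands level with compound 1, within the scatter. Compound 3 `Cc1cnc(Nc2ccc(C#N)cc2)nc1Nc1c(F)cc(-c2ccco2)cc1F` differs from compound 2 by furan-2-yl in place of pyrimidin-5-yl on an aromatic carbon, with furan-2-yl in place of pyrimidin-5-yl on an aromatic carbon. Going by the values given here, the only measured step that bears on this is a 1.2-fold lower number from compound 1 to compound 2 (0.09 log units; within the scatter), and it brought in no five-membered aromatic ring, so it is a loose guide. No step beyond the scatter is expected in this assay. The expected step is a 1.1-fold higher number from compound 2 to compound 3 (0.05 log units; within the scatter). For compound 3 the estimated value is 1000 nM, with a range of 400 nM to 3000 nM.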

Compound 3, half-maximal cytotoxic concentration: 8100 nM
For compound 3 the middle estimate is 8.1-fold (0.91 log units) below the measured one, outside the stated range (above it).
By their numbers in this assay, from the lowest: compounds 2 and 1 (each within the scatter of the next); then compound 3.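

In this assay this position proves sensitive to the ring placed on it: furan-2-yl gives a 9.0-fold higher number from compound 2 to compound 3 (0.95 log units; beyond the scatter) and a 7.4-fold higher number from compound 1 to compound 3 (0.87 log units; beyond the scatter), a move towards lower toxicity in this test, whereas the exchange between the two six-membered aromatic rings stayed within the scatter. Nothing at hand explains this shift.

As far as these compounds go, whether the shift belongs to furan-2-yl alone or to five-membered aromatic rings generally remains open. So does the outcome at this position with an amine or a carboxylic acid on the ring carbon.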